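Working notes: aryl change from compound 1 to compound 3

The compounds below may be only part of what the source reports. "The series", "measured", "known", "first", "only" and "open" are said of these compounds alone.

Among the compounds with values here, in a functional assay on SK-N-SH cells (Homo sapiens) for inhibition, read by MTT assay, with a stated time of 72 h, tested at 50 uM (a lower number here means less inhibition of growth, a higher number more inhibition of growth at the concentration tested), compound 1 `C=CCc1ccc(OCc2cn(-c3ccccc3Cl)nn2)c(O)c1` gives 42.8% as the lower of the two numbers so far. Compound 2 `C#CCOc1ccc(CC=C)cc1O` stands higher at 88.4% and the gap lies beyond the scatter. Compound 3 `C=CCc1ccc(OCc2cn(-c3cccc(C#N)c3)nn2)c(O)c1` is not yet measured and carries 3-cyanophenyl in place of 2-chlorophenyl on an aromatic nitrogen relative to compound 1. Within the data shown here, no measured pair shows this change, so the data give no size for it. In this assay the expected move is a number 2.2 percentage points higher from compound 1 to compound 3 (within the scatter) with no shift beyond the scatter in either direction. In this assay the estimate for compound 3 is 45% with an expected range from 25% to 68%.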

Compound 3, percent growth inhibition at one concentration: 78.8%
The estimate for compound 3 lay 33.8 percentage points below the measured number; the measured number lies above the stated range.
By their numbers in this assay, from the lowest: compound 1; then compounds 3 and 2 (each within the scatter of the next).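

In this assay, the group on the aromatic nitrogen now has a measured effect: 3-cyanophenyl in place of 2-chlorophenyl gives a number 36 percentage points higher from compound 1 to compound 3 (beyond the scatter). Within the data shown here, this is the first step read at this position, and it is large, so the growth inhibition of this series depends on this aryl group. No available data bear on the reason for this step.

The step changes both the substituent and its place on the phenyl ring, and the two remain unseparated. A 3-chlorophenyl or 2-cyanophenyl group on the same nitrogen would tell them apart.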